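Piperazine nitrogen substituent in the tetrahydroquinoline amine series

The source may report more compounds than this note shows. Statements on the series, on what has been measured and on what is new or still open speak of the compounds shown alone.

Measured so far:
compound 1 `c1cnc2c(c1)CN[C@H](CN(CCCN1CCNCC1)[C@H]1CCCc3cccnc31)C2`: 87%
compound 2 `CCN1CCN(CCCN(C[C@H]2Cc3ccccc3CN2)[C@H]2CCCc3cccnc32)CC1`: 1%
compound 3 `c1cnc2c(c1)CCC[C@@H]2N(CCCN1CCNCC1)Cc1cc2ccccc2cn1`: 59%

In an ADME assay on microsomes from liver (Rattus norvegicus) for metabolic stability, read by LC-MS, with a stated time of 10 min, tested at 0.5 uM (a higher number here means that more of the compound is left, a lower number that less of the compound is left), compound 2 gives 1%, the lowest of the three numbers. Compound 3 gives 59% and compound 1 gives 87%, each beyond the scatter above compound 2. Among the compounds with values here, the only measured step, a number 28 percentage points lower from compound 1 to compound 3 (beyond the scatter), concerns an exchange on a saturated chain carbon bound to an amine nitrogen and therefore does not touch the site of the present change.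

Compound 4 `c1ccc2c(c1)CN[C@@H](CN(CCCN1CCN(C3CC3)CC1)[C@H]1CCCc3cccnc31)C2` differs from compound 2 by cyclopropyl in place of ethyl on an amine nitrogen in a ring. Within the data shown here, no measured pair shows this exchange, so no size of step in this assay can be read from the data; the only guidance is that compound 2 sits at the low end of the range. With nothing pointing either way, the step of a number 7 percentage points higher from compound 2 to compound 4 (within the scatter) is expected to stay within the scatter. Compound 4 is accordingly estimated at 8%, with a range from 0% to 30%.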

Compound 4, percent of the compound remaining: 2%
Beside the measured number, compound 4's estimate is 6 percentage points above it; measured number inside the range.
By their numbers in this assay, from the lowest: compounds 2 and 4 (each within the scatter of the next); then compound 3; then compound 1.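

In this assay, within the data shown here, cyclopropyl in place of ethyl on an amine nitrogen in a ring gives a number 1 percentage points higher from compound 2 to compound 4 (within the scatter), the only step measured at this position, and it stays within the scatter. This exchange therefore leaves both compounds at the bottom of the series, so the added three-membered ring does not separate compound 4 from compound 2 in this read-out. No measured evidence bears on what lies behind either number.

Still open, from the compounds shown here alone, is whether any group on this nitrogen moves the number, for example an acetyl group or a 2-hydroxyethyl chain. Compound 1 and compound 3 carry no group on this nitrogen but also differ from compound 2 and compound 4 elsewhere, so the contribution of the nitrogen substituent alone cannot be read from them.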